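Swapping Fluoro for Methoxy on a Bis-Sulfonamide Core

The source may report more compounds than this note shows. Statements on the series, on what has been measured and on what is new or still open speak of the compounds shown alone.

Compound 1, `O=S(=O)(Nc1ccccc1NS(=O)(=O)c1ccc(Cl)cc1)c1ccc(F)cc1`, gives 27300 nM.
Compound 2, `COc1ccc(S(=O)(=O)Nc2ccccc2NS(=O)(=O)c2ccc(F)cc2)cc1`, gives 17200 nM.
Compound 3, `O=S(=O)(Nc1ccccc1NS(=O)(=O)c1cccc(Br)c1)c1ccc(F)cc1`, gives 16200 nM.

These three share one core and were all measured in an assay for binding affinity to protein lin-28 homolog A (Mus musculus), with a stated time of 1 h; on this read-out lower numbers stand for stronger inhibition and higher numbers for weaker inhibition. Compound 2 stands second highest of the three numbers; its nearest neighbour is told by a 1.1-fold lower number from compound 2 to compound 3 (0.03 log units; within the scatter), and its furthest by a 1.6-fold lower number from compound 1 to compound 2 (0.20 log units; within the scatter), so all three sit within the scatter of one another.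

Compound 4, `COc1ccc(S(=O)(=O)Nc2ccccc2NS(=O)(=O)c2ccc(OC)cc2)cc1`, has not yet been measured. It differs from compound 2 in one place: methoxy in place of fluoro on an aromatic carbon. For the measured compounds named here, only one measured step bears on this: a 1.6-fold lower number from compound 1 to compound 2 (0.20 log units; within the scatter), which also brought a methoxy onto an aromatic carbon and stayed within the scatter. Going by the values given here, no measured step removes a fluoro, so that side of the change is untested. On this basis the expected step is a 1.1-fold lower number from compound 2 to compound 4 (0.03 log units; within the scatter), which is not expected to go beyond the scatter in either direction. Compound 4 is therefore estimated at 16000 nM in this assay, with a range from 7000 nM to 35000 nM.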

Compound 4, half-maximal inhibitory concentration: 16700 nM
Compound 4: the middle estimate sits 1.0-fold (0.02 log units) below what was measured; the range from low to high includes it.
By their numbers in this assay, from the lowest: compounds 3, 4, 2 and 1 (each within the scatter of the next).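

Compound 2 carries a 4-fluorophenyl group where compound 4 carries a 4-methoxyphenyl group, and in this assay this exchange gives a 1.0-fold lower number from compound 2 to compound 4 (0.01 log units; within the scatter) and so stays within the scatter. For the compounds shown here, this is the first direct reading of fluoro leaving this position, which the earlier compounds left untested, and it shows that the number holds when methoxy takes its place, even with a 4-methoxyphenyl group now on each sulfonyl sulfur. No measured evidence accounts for this flat result.

From the compounds shown here alone, only fluoro and methoxy have been compared directly at this position, so it remains open whether an amine, a carboxylic acid or a longer chain such as butoxy would move the number beyond the scatter. Whether any change at this position can do so is also unanswered.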